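A few compounds are considered here, and "the series" means these few. Any claim that something is new, unique, unknown or untested is made for them only; others in the source may bear on it.

Measured compounds:
compound 1, `COc1ccc(/C=C/c2cc(/C=C/c3ccc(OC)c(OC)c3)nc(OCCCCCCBr)n2)cc1OC`: > 20000 nM
compound 2, `COc1cc(/C=C/c2cc(/C=C/c3cc(OC)c(OC)c(OC)c3)nc(OCCCCBr)n2)cc(OC)c1OC`: > 20000 nM

In a functional assay on A549 cells (Homo sapiens) for cytotoxicity, read by fluorescence and resazurin assay, with a stated time of 48 h (a higher number here means a weaker inhibitor, a lower number a stronger inhibitor), compound 1 gives only a limit, > 20000 nM, not a number. Compound 2 likewise gives only a limit in this assay, > 20000 nM. For the measured compounds named here, both measured values therefore sit at the limit of > 20000 nM in this assay, at which 2 of the 2 values shown sit, so neither compound shows a measurable effect in this assay, and no step between measured compounds can be computed from them.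

Compound 3, `COc1ccc(/C=C/c2cc(/C=C/c3ccc(OC)c(OC)c3)nc(OCCCCBr)n2)cc1OC`, has not yet been measured in this assay. It differs from compound 1 in one place, (bromo in place of 2-bromoethyl on a saturated chain carbon, four bonds along the chain from an oxygen on an aromatic ring), which shortens the bromoalkyl chain on the shared core. Compound 2 already carries this shorter chain, although it differs from compound 3 elsewhere as well, and compound 2 sits at the same limit as compound 1.

The step from compound 1 to compound 3 is expected to be a step that the limit leaves unreadable from compound 1 to compound 3, that is, no change beyond the scatter. Compound 3 is estimated to give 30000 nM in this assay, within a range from 12000 nM to 100000 nM, and most likely again only a limit rather than a number.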

Compound 3, half-maximal inhibitory concentration: > 20000 nM
Compound 3: only a limit was reported (the forecaster's own chance of this, stated with the estimate: 85%); the middle value lies beyond the limit too.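

Compound 1 and compound 3 each give only a limit in this assay, so no step can be read between them. The compounds shown leave open whether the length of the bromoalkyl chain on the shared core makes any difference to the strength of inhibition in this assay.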